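Swapping Trifluoromethyl for Cyano on the Benzyl Ring

The source may report more compounds than this note shows. Statements on the series, on what has been measured and on what is new or still open speak of the compounds shown alone.

Compound 1, `CCN(CC)c1ccc2cc(C(=O)c3ccc(N4CCN(C(=O)CN5CCN(C(=O)/C=C/c6ccccc6)CC5)CC4)cc3)oc2c1`: in a functional assay on A549 cells (Homo sapiens) for cytotoxicity, read by MTT assay, with a stated time of 48 h (on this read-out higher numbers stand for weaker inhibition and lower numbers for stronger inhibition), compound 1 gives 9450 nM.
Compound 2, `CCN(CC)c1ccc2cc(C(=O)c3ccc(N4CCN(C(=O)CN5CCN(Cc6ccc(F)c(F)c6)CC5)CC4)cc3)oc2c1`: compound 2 gives 5440 nM.
Compound 3, `CCN(CC)c1ccc2cc(C(=O)c3ccc(N4CCN(C(=O)CN5CCN(Cc6ccc(C(F)(F)F)cc6)CC5)CC4)cc3)oc2c1`: compound 3 gives 20100 nM.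

All three share the same core and differ only in the group on the outer ring nitrogen. Compound 3 stands at the highest of the three numbers: a 2.1-fold higher number from compound 1 to compound 3 (0.33 log units; beyond the scatter) and a 3.7-fold higher number from compound 2 to compound 3 (0.57 log units; beyond the scatter), both beyond the scatter, though modest.

Compound 4, `CCN(CC)c1ccc2cc(C(=O)c3ccc(N4CCN(C(=O)CN5CCN(Cc6ccc(C#N)cc6)CC5)CC4)cc3)oc2c1`, is the next step from compound 3: cyano in place of trifluoromethyl on an aromatic carbon. Among the compounds with values here, no measured step touches the trifluoromethyl group itself, so nothing bears on this change directly. The nearest comparison is the change of substituents on the same benzyl ring, which gave a 3.7-fold higher number from compound 2 to compound 3 (0.57 log units; beyond the scatter). A change of similar modest size seems plausible here, and because compound 3 already sits at 20100 nM, the highest number seen, a movement back toward the other two compounds looks somewhat more likely than a further rise, though the direction is uncertain.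

Compound 4 is therefore expected to give about 12000 nM, with a likely range from 4000 nM to 35000 nM. This estimate amounts to an expected step of a 1.7-fold lower number from compound 3 to compound 4 (0.22 log units; within the scatter).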

Compound 4, half-maximal inhibitory concentration: 17400 nM
Beside the measured number, compound 4's estimate is 1.5-fold (0.16 log units) below it, and the stated range covers the measured number.
By their numbers in this assay, from the lowest: compounds 2, 1, 4 and 3 (each within the scatter of the next, the first and the last beyond it).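

In this assay, cyano in place of trifluoromethyl on this aromatic carbon, para to a large group, gives a 1.2-fold lower number from compound 3 to compound 4 (0.06 log units; within the scatter), so the two groups cannot be told apart here, even though cyano has fewer heavy atoms and carries a hydrogen-bond acceptor. The gap that separated compound 3 from the 3,4-difluorobenzyl compound also remains with the new group, at a 3.2-fold higher number from compound 2 to compound 4 (0.50 log units; beyond the scatter), whereas set against the (2-phenylethenyl)carbonyl compound, the 4-cyanobenzyl group gives a 1.8-fold higher number from compound 1 to compound 4 (0.27 log units; within the scatter), which stays within the scatter, unlike the step to compound 3. Nothing in the available data explains why cyano and trifluoromethyl read alike at this position.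

The compounds shown leave open how this aromatic carbon would respond to a very different group, such as an amine or a carboxylic acid, so the flat result may hold only for this pair. Also open, on these data alone, is whether a single fluorine on the same carbon would read like compound 2 or like compound 3 and compound 4.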